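Chloro in Place of Hydroxy on the Aryl Ketone

The compounds below may be only part of what the source reports. "The series", "measured", "known", "first", "only" and "open" are said of these compounds alone.

For the measured compounds named here, compound 2 `O=C(/C=C/c1cc2ccccc2[nH]c1=O)c1ccc(O)cc1` gives 3200 nM in a functional assay on RPMI-8226 cells (Homo sapiens) for cytotoxicity, read by sulforhodamine B assay, with a stated time of 24 h (a lower number here means a stronger inhibitor of growth, a higher number a weaker inhibitor of growth), the highest of the two numbers so far, though compound 1 `COc1ccc(C(=O)/C=C/c2cc3ccccc3[nH]c2=O)cc1` at 2790 nM lies within the scatter, the step of a 1.1-fold higher number from compound 1 to compound 2 (0.06 log units; within the scatter) being small. Compound 3 `O=C(/C=C/c1cc2ccccc2[nH]c1=O)c1ccc(Cl)cc1` differs from compound 2 by chloro in place of hydroxy on an aromatic carbon. Going by the values given here, no measured step exchanges hydroxy for chloro; only one step bears on the place, and because a 1.1-fold higher number from compound 1 to compound 2 (0.06 log units; within the scatter) stayed within the scatter, change at this place looks tolerated. Compound 3 is therefore expected to move little, a step of a 1.3-fold lower number from compound 2 to compound 3 (0.11 log units; within the scatter) in this assay. The estimate for compound 3 is 2500 nM, between 800 nM and 8000 nM.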

Compound 3, concentration for 50% growth inhibition: 2230 nM
Compound 3: middle estimate off by 1.1-fold (0.05 log units), on the high side; measured number inside the range.
By their numbers in this assay, from the lowest: compounds 3, 1 and 2 (each within the scatter of the next).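

Chloro on this aromatic carbon, para to a large group, stays within the scatter of both oxygen-bearing groups in this assay (a 1.4-fold lower number from compound 2 to compound 3 (0.16 log units; within the scatter)) and (a 1.3-fold lower number from compound 1 to compound 3 (0.10 log units; within the scatter)). The earlier step changed only what sits on the oxygen, whereas here the oxygen itself is gone, along with the hydrogen-bond donor and acceptor counted for hydroxy. Nothing given here accounts for this tolerance. As far as these compounds go, whether an amine, a carboxylic acid or a longer chain on this carbon would also stay within the scatter remains open.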